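Azole in place of carboxyaryl on the shared core

The source may report more compounds than this note shows. Statements on the series, on what has been measured and on what is new or still open speak of the compounds shown alone.

Compound 1, `CCC(C)(C)Cc1c[nH]c(CCc2ccc(-n3ncnn3)cc2)n1`, compound 2, `CCC(C)(C)Cc1c[nH]c(CCc2ccc(-c3cccnc3C(=O)O)cc2)n1`, and compound 3, `CCC(C)(C)Cc1c[nH]c(CCc2ccc(-c3ccccc3C(=O)O)cc2)n1`, share one core and differ only in the group on the aromatic carbon. In a functional assay on HEK293 cells for agonist activity at Bombesin receptor subtype-3 (Mus musculus), read by luminescence and calcium flux, with a stated time of 10 min (on this read-out higher numbers stand for an effect only at larger amounts of compound and lower numbers for an effect already at smaller amounts), compound 1 gives 99 nM, compound 2 gives 97 nM and compound 3 gives 94 nM; the three numbers sit within the scatter of one another, as seen in a 1.1-fold lower number from compound 1 to compound 3 (0.02 log units; within the scatter) and a 1.0-fold lower number from compound 2 to compound 3 (0.01 log units; within the scatter). Compound 4, `CCC(C)(C)Cc1c[nH]c(CCc2ccc(-n3cncn3)cc2)n1`, is not yet measured. It differs from compound 3 by 1H-1,2,4-triazol-1-yl in place of 2-carboxyphenyl on an aromatic carbon. For the measured compounds named here, the nearest precedent is a 1.1-fold lower number from compound 1 to compound 3 (0.02 log units; within the scatter), where 2H-tetrazol-2-yl stood against 2-carboxyphenyl with no step beyond the scatter, and a 1.0-fold lower number from compound 1 to compound 2 (0.01 log units; within the scatter) shows the same. No step beyond the scatter is therefore expected, a 1.0-fold higher number from compound 3 to compound 4 (0.00 log units; within the scatter). Compound 4 is estimated at 95 nM, with a range from 45 nM to 200 nM.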

Compound 4, half-maximal effective concentration: 121 nM
For compound 4 the middle estimate is 1.3-fold (0.11 log units) below the measured one; the measured number falls inside the stated range.
By their numbers in this assay, from the lowest: compounds 3, 2, 1 and 4 (each within the scatter of the next).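

In this assay the aromatic carbon para to a large group also accepts 1H-1,2,4-triazol-1-yl, with every step within the scatter: a 1.3-fold higher number from compound 3 to compound 4 (0.11 log units; within the scatter), a 1.2-fold higher number from compound 2 to compound 4 (0.10 log units; within the scatter) and a 1.2-fold higher number from compound 1 to compound 4 (0.09 log units; within the scatter). A second azole, with 5 heavy atoms against the 9 of 2-carboxyphenyl, therefore leaves this read-out within the scatter of the three earlier groups. Nothing available bears on the reason for this tolerance. Open, from the compounds shown here alone, is whether an amine, a primary amide or a longer chain at this position would also stay within the scatter. The compounds shown also leave open whether this holds with another group on the shared core.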